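Predicting a Fourth Compound from Three Cytotoxicity Values

The source may report more compounds than this note shows. Statements on the series, on what has been measured and on what is new or still open speak of the compounds shown alone.

Three compounds were measured in a functional assay on A549 cells (Homo sapiens) for cytotoxicity, read by MTT assay, with a stated time of 72 h; on this read-out higher numbers stand for weaker inhibition and lower numbers for stronger inhibition:

Compound 1, `COc1cc(/C=N/NC(=O)Nc2cc3c(Nc4ccc(F)c(Cl)c4)ncnc3cc2O[C@H]2CCOC2)cc(OC)c1OC`, gives 26400 nM.
Compound 2, `O=C(N/N=C/c1ccc(O)c(Br)c1)Nc1cc2c(Nc3ccc(F)c(Cl)c3)ncnc2cc1O[C@H]1CCOC1`, gives 4310 nM.
Compound 3, `COc1cc2ncnc(Nc3ccc(F)c(Cl)c3)c2cc1NC(=O)N/N=C/c1cc(OC)c(OC)c(OC)c1`, gives 32100 nM.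

Compound 2 differs from compound 1 in one place: 3-bromo-4-hydroxyphenyl in place of 3,4,5-trimethoxyphenyl on a carbon with a double bond to nitrogen. This change brought a 6.1-fold lower number from compound 1 to compound 2 (0.79 log units; beyond the scatter), so the hydroxy-bearing ring gave a clearly stronger effect on cell growth than the trimethoxy-bearing ring.

Compound 3 differs from compound 1 in a different place: methyl in place of oxolan-3-yl on an oxygen on an aromatic ring. Here the step was a 1.2-fold higher number from compound 1 to compound 3 (0.08 log units; within the scatter), so the two cores behave alike on this read-out.

Compound 4, `COc1cc2ncnc(Nc3ccc(F)c(Cl)c3)c2cc1NC(=O)N/N=C/c1ccc(O)c(Br)c1`, is not yet measured. It stands to compound 3 as compound 2 stands to compound 1: 3-bromo-4-hydroxyphenyl in place of 3,4,5-trimethoxyphenyl on a carbon with a double bond to nitrogen. The place of the change is the same in both pairs, so it is the same change on the other core. Because the first occurrence gave a 6.1-fold lower number from compound 1 to compound 2 (0.79 log units; beyond the scatter) and the two cores differ only within the scatter, a step of similar size is expected, namely a 5.8-fold lower number from compound 3 to compound 4 (0.77 log units; beyond the scatter). Compound 4 is therefore estimated at 5500 nM, most likely between 2500 nM and 12000 nM.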

Compound 4, half-maximal inhibitory concentration: 28600 nM
Compound 4: middle estimate off by 5.2-fold (0.72 log units), on the low side; the measured number lies above the stated range.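

On the core of compound 3, the swap to 3-bromo-4-hydroxyphenyl brought only a 1.1-fold lower number from compound 3 to compound 4 (0.05 log units; within the scatter), so the clear drop seen on the core of compound 1 did not carry over: the same change on two cores in this assay, a 6.1-fold lower number (0.79 log units; beyond the scatter) from compound 1 to compound 2 and a 1.1-fold lower number (0.05 log units; within the scatter) from compound 3 to compound 4, 5.5-fold (0.74 log units) apart, beyond the scatter of two such steps.

Read the other way, methyl in place of oxolan-3-yl made no clear difference with the 3,4,5-trimethoxyphenyl group, yet with 3-bromo-4-hydroxyphenyl it gave a 6.6-fold higher number from compound 2 to compound 4 (0.82 log units; beyond the scatter): the same change on two cores in this assay, a 1.2-fold higher number (0.08 log units; within the scatter) from compound 1 to compound 3 and a 6.6-fold higher number (0.82 log units; beyond the scatter) from compound 2 to compound 4, 5.5-fold (0.74 log units) apart, beyond the scatter of two such steps.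

So in this assay the two changes do not act independently, and a step measured on one core cannot simply be carried to the other; these four compounds do not show why, nor whether the same holds for other groups.

The compounds shown leave open whether the stronger effect of compound 2 needs the oxolan-3-yl group itself or would also appear with a longer chain, such as ethyl or a chain ending in an amine, on that oxygen. They also leave open whether it needs both the bromine and the hydroxy group on the ring.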